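The source may report more compounds than this note shows. Statements on the series, on what has been measured and on what is new or still open speak of the compounds shown alone.

Values measured in a functional assay on B16-F1 cells (Mus musculus) for antiproliferative activity, read by MTT assay, with a stated time of 72 h (on this read-out higher numbers stand for weaker inhibition and lower numbers for stronger inhibition), for the three compounds
- Compound 1 `C/C=C1/[C@H](O[C@@H]2O[C@H](CO)[C@@H](O)[C@H](O)[C@H]2O)OC=C(C(=O)OC)[C@H]1CC(=O)OCCC1CCCCC1` gives 5040 nM
- Compound 2 `C/C=C1/[C@H](O[C@@H]2O[C@H](CO)[C@@H](O)[C@H](O)[C@H]2O)OC=C(C(=O)OC)[C@H]1CC(=O)OCCc1ccc(O)c(O)c1` gives 284000 nM
- Compound 3 `C/C=C1/[C@H](O[C@@H]2O[C@H](CO)[C@@H](O)[C@H](O)[C@H]2O)OC=C(C(=O)OC)[C@H]1CC(=O)OCCC(C)C` gives 39100 nM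

Compound 3 holds the middle place among these numbers. On one side lies a 7.8-fold higher number from compound 1 to compound 3 (0.89 log units; beyond the scatter) and on the other 7.3-fold lower number from compound 2 to compound 3 (0.86 log units; beyond the scatter), both modest and beyond the scatter. The next compound, compound 4 `C/C=C1/[C@H](O[C@@H]2O[C@H](CO)[C@@H](O)[C@H](O)[C@H]2O)OC=C(C(=O)OC)[C@H]1CC(=O)OCCc1ccccc1`, carries phenyl in place of isopropyl on a saturated chain carbon, two bonds along the chain from an oxygen next to a carbonyl group.

All three measured steps were made at this same place, and they give no single trend for ring groups. Compound 1 with cyclohexyl stands lower than compound 3, while compound 2 with 3,4-dihydroxyphenyl stands higher. The span between those two ring compounds is large, with a 56-fold higher number from compound 1 to compound 2 (1.75 log units; beyond the scatter) as its measure. Phenyl shares the six-membered ring of compound 1 and the aromatic ring of compound 2, so a result inside that span is expected, with a small to modest move toward lower numbers in this assay as the likeliest outcome.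

The expected change is a 2.2-fold lower number from compound 3 to compound 4 (0.34 log units; beyond the scatter) as estimated here. For compound 4 the estimated value is 18000 nM, with an expected range from 5000 nM to 70000 nM and the measurement still to come.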

Compound 4, half-maximal inhibitory concentration: 41000 nM
Compound 4: middle estimate off by 2.3-fold (0.36 log units), on the low side, and the stated range covers the measured number.
By their numbers in this assay, from the lowest: compound 1; then compounds 3 and 4 (each within the scatter of the next); then compound 2.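

In this assay the change from isopropyl to phenyl at this place, on a saturated chain carbon, two bonds along the chain from an oxygen next to a carbonyl group, lies within the scatter (a 1.0-fold higher number from compound 3 to compound 4 (0.02 log units; within the scatter)), so a branched open chain and a plain aromatic ring cannot be told apart here. The same phenyl compound is separated from both other ring compounds by steps beyond the scatter (an 8.1-fold higher number from compound 1 to compound 4 (0.91 log units; beyond the scatter); a 6.9-fold lower number from compound 2 to compound 4 (0.84 log units; beyond the scatter)), which shows that among these four compounds the presence of a six-membered ring does not by itself set the level: compound 1 with cyclohexyl and compound 2 with 3,4-dihydroxyphenyl fall on opposite sides of compound 4. The gap to compound 2 also ties the two hydroxy groups on the ring to a large part of the span seen earlier, while nothing available here bears on why these groups differ.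

From the compounds shown here alone, whether a single hydroxy group on the phenyl ring would give part of that gap remains open. So does how a longer chain such as octyl, or an amine or a carboxylic acid at the end of the chain, would stand against cyclohexyl.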